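Hydroxy for fluoro on the hydrazone aryl ring

The source may report more compounds than this note shows. Statements on the series, on what has been measured and on what is new or still open speak of the compounds shown alone.

Three compounds share one core and differ only in the aryl group on the carbon with a double bond to nitrogen. In a functional assay on MKN-45 cells (Homo sapiens) for cytotoxicity, read by MTT assay, with a stated time of 72 h (on this read-out lower numbers stand for stronger inhibition and higher numbers for weaker inhibition), compound 3 `CN(C)CCn1cnnc1-c1cc(Oc2ccc(NC(=O)N/N=C/c3ccc(O)c(F)c3)cc2F)ccn1` gives 1970 nM, the highest of the three numbers. Compound 1 `CN(C)CCn1cnnc1-c1cc(Oc2ccc(NC(=O)N/N=C/c3cccc(O)c3)cc2F)ccn1` gives 1370 nM, and the step of a 1.4-fold higher number from compound 1 to compound 3 (0.16 log units; within the scatter) lies within the scatter. Compound 2 `CN(C)CCn1cnnc1-c1cc(Oc2ccc(NC(=O)N/N=C/c3cccc(Cl)c3Cl)cc2F)ccn1` gives 51 nM, and the step of a 39-fold higher number from compound 2 to compound 3 (1.59 log units; beyond the scatter) is large. Compound 4 `CN(C)CCn1cnnc1-c1cc(Oc2ccc(NC(=O)N/N=C/c3ccc(O)c(O)c3)cc2F)ccn1` differs from compound 3 by hydroxy in place of fluoro on an aromatic carbon. Among the compounds with values here, both hydroxy-bearing compounds 1 and 3 sit near the weak end, and the only nearby step, a 1.4-fold higher number from compound 1 to compound 3 (0.16 log units; within the scatter), was within the scatter, so for compound 4 a step of a 1.3-fold higher number from compound 3 to compound 4 (0.12 log units; within the scatter) is expected. Compound 4 is therefore estimated at 2600 nM in this assay, with a range from 1000 nM to 6500 nM.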

Compound 4, half-maximal inhibitory concentration: 3240 nM
Compound 4: the middle estimate sits 1.2-fold (0.10 log units) below what was measured, and the stated range covers the measured number.
By their numbers in this assay, from the lowest: compound 2; then compounds 1, 3 and 4 (each within the scatter of the next, the first and the last beyond it).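

In this assay, hydroxy in place of fluoro on this aromatic carbon stays within the scatter (a 1.6-fold higher number from compound 3 to compound 4 (0.22 log units; within the scatter)), so 3-fluoro-4-hydroxyphenyl and 3,4-dihydroxyphenyl cannot be told apart here. Hydroxy in place of hydrogen on the ring of compound 1 gives a modest step beyond the scatter (a 2.4-fold higher number from compound 1 to compound 4 (0.37 log units; beyond the scatter)), while the gap to the 2,3-dichlorophenyl compound remains large (a 64-fold higher number from compound 2 to compound 4 (1.80 log units; beyond the scatter)). No evidence at hand accounts for these steps.

The compounds shown leave open whether methoxy or an amine on this aromatic carbon would stay with compounds 3 and 4. They also leave open whether chloro there would move the number towards that of compound 2.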